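Swapping 2-chloro-4-fluorophenyl for 4-hydroxyphenyl in a growth-inhibition series

The source may hold more compounds than are shown below. What is called first, only, known or untested is meant among the compounds shown, and "the series" means these compounds.

Values so far in a functional assay on MCF7 cells (Homo sapiens) (a higher number here means a weaker inhibitor of growth, a lower number a stronger inhibitor of growth), for three compounds:
compound 1 `O=S(=O)(/C=C/c1ccc(F)cc1)Cc1ccc(Nc2ncnc3ccccc23)cc1` gives 16000 nM
compound 2 `O=S(=O)(/C=C/c1ccc(F)cc1F)Cc1ccc(Nc2ncnc3ccccc23)cc1` gives > 100000 nM (a limit of the assay, not a number)
compound 3 `O=S(=O)(/C=C/c1ccc(F)cc1Cl)Cc1ccc(Nc2ncnc3ccccc23)cc1` gives 21000 nM

Compound 3 stands level with compound 1 in this assay since the gap is a 1.3-fold higher number from compound 1 to compound 3 (0.12 log units; within the scatter) and no order can be read from it. The entry for compound 2 is only a limit.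

Compound 4 `O=S(=O)(/C=C/c1ccc(O)cc1)Cc1ccc(Nc2ncnc3ccccc23)cc1` has not been measured yet. Its difference from compound 3 is 4-hydroxyphenyl in place of 2-chloro-4-fluorophenyl on a double-bonded chain carbon bound to a double-bonded chain carbon with 4-hydroxyphenyl in place of 2-chloro-4-fluorophenyl on a double-bonded chain carbon bound to a double-bonded chain carbon.

Within the data shown here, no measured compound carries 4-hydroxyphenyl, so the only guide is how far changes to this same group have moved the number. Chloro in place of hydrogen gave a 1.3-fold higher number from compound 1 to compound 3 (0.12 log units; within the scatter) while fluoro in place of hydrogen gave an at least 6.2-fold higher number from compound 1 to compound 2 (0.79 log units; beyond the scatter) and chloro in place of fluoro gave an at least 4.7-fold lower number from compound 2 to compound 3 (0.67 log units; beyond the scatter) in these three compounds. Both larger steps rest on the limit of > 100000 nM in this assay, at which 1 of the 3 values shown sits, and so give no exact size. Such changes can therefore be silent or large, and they settle no direction for compound 4. The expected size is modest, namely a 1.1-fold lower number from compound 3 to compound 4 (0.02 log units; within the scatter) with real uncertainty on either side. For compound 4 the estimated value is 20000 nM with an expected range from 5000 nM to 80000 nM in this assay.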

Compound 4, concentration for 50% growth inhibition: 100000 nM
Compound 4: middle estimate off by 5.0-fold (0.70 log units), on the low side; the whole stated range lies below it.
By their numbers in this assay, from the lowest: compounds 1 and 3 (each within the scatter of the next); then compound 4.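

In this assay, hydroxy in place of fluoro gives a 6.3-fold higher number from compound 1 to compound 4 (0.80 log units; beyond the scatter), and 4-hydroxyphenyl in place of 2-chloro-4-fluorophenyl gives a 4.8-fold higher number from compound 3 to compound 4 (0.68 log units; beyond the scatter), so this new group weakens growth inhibition relative to both compounds, in steps beyond the scatter. Among these compounds, until now, every step on this ring that went beyond the scatter ran through compound 2, so these are the first steps there with a readable size, and they show that the group on the ring can matter to this assay. 4-Hydroxyphenyl in place of 2,4-difluorophenyl gives a number no higher from compound 2 to compound 4 (the limit leaves the size open). The size of that step cannot be read, because compound 2 carries a limit of the assay and not a number: the limit of > 100000 nM in this assay, at which 1 of the 4 values shown sits.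

From the compounds shown here alone, whether the weaker number comes from the hydroxy itself or from the loss of the fluoro stays open, and a plain phenyl, a methoxy or an amine in the same place would help to tell these apart. Going by these compounds, it is also open whether any group on this ring can bring the number clearly lower than that of compound 1.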